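The source may report more compounds than this note shows. Statements on the series, on what has been measured and on what is new or still open speak of the compounds shown alone.

Measured so far:
compound 1 `COc1ccccc1C1C(C#N)=C(N)N(c2ccc(S(N)(=O)=O)cc2)C2=C1C(=O)CCC2` — 0%
compound 2 `N#CC1=C(N)N(c2ccc(S(N)(=O)=O)cc2)C2=C(C(=O)CCC2)C1c1ccc(Cl)cc1Cl` — 95%

In a functional assay on Ehrlich cells (Mus musculus) for antiproliferative activity, read by trypan blue exclusion, with a stated time of 2 h, tested at 100 ug/mL (on this read-out lower numbers stand for a weaker effect and higher numbers for a stronger effect at the one concentration tested), compound 2 stands highest of the two numbers; its nearest neighbour is compound 1, and the gap between them is a number 95 percentage points higher from compound 1 to compound 2 (beyond the scatter), beyond the scatter. Compound 3 `Cc1ccoc1C1C(C#N)=C(N)N(c2ccc(S(N)(=O)=O)cc2)C2=C1C(=O)CCC2` has not been measured. It differs from compound 2 by 3-methylfuran-2-yl in place of 2,4-dichlorophenyl on a saturated ring carbon. Going by the values given here, the only measured step that bears on this place is the one from compound 1 to compound 2, a number 95 percentage points higher from compound 1 to compound 2 (beyond the scatter), and it shows that an exchange of the group on this saturated ring carbon can move the read-out across nearly the whole scale. Among the compounds with values here, no measured compound carries a five-membered aromatic ring with one hetero atom at this place, so the direction for compound 3 rests on a single pair in which one aromatic group gave the top number and the other the bottom. A step down of about a number 55 percentage points lower from compound 2 to compound 3 (beyond the scatter) is therefore expected, with wide uncertainty. Compound 3 is accordingly estimated at 40%, within 0% to 95%.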

Compound 3, a percentage reported as activity, at one concentration (the size of the read-out at that concentration, not a potency): 45%
Beside the measured number, compound 3's estimate is 5 percentage points below it; the range from low to high includes it.
By their numbers in this assay, from the lowest: compound 1; then compound 3; then compound 2.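

With 3-methylfuran-2-yl on the saturated ring carbon, the read-out in this assay falls between the two earlier extremes: there is a number 50 percentage points lower from compound 2 to compound 3 (beyond the scatter), and also a number 45 percentage points higher from compound 1 to compound 3 (beyond the scatter). The group at this place therefore does more than switch the effect between full and none, and both steps are large. A five-membered aromatic ring with 1 hetero atom is also tolerated here with a partial effect, and no measurement on these compounds accounts for the ordering of the three groups.

The compounds shown leave open which part of each exchange carries the change, as ring size, the ring oxygen, the methyl group and the two chlorine atoms all change together between compound 2 and compound 3. Unsubstituted phenyl, 4-chlorophenyl, furan-2-yl without the methyl group or a saturated cyclohexyl group at this place would separate these parts, and since the read-out comes from one concentration, the potency of compound 3 and compound 2 also remains open.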